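This account rests on a few compounds, and the source may have more. Where it says the series, first, only, none or still open, it means among the compounds named here.

Measured so far in a functional assay on HCT-116 cells (Homo sapiens) for inhibition, read by MTT assay, with a stated time of 24 h, tested at 10 uM; on this read-out higher numbers stand for more inhibition of growth at the one concentration tested and lower numbers for less inhibition of growth:
compound 1 `CS(=O)(=O)c1ccc(-c2cnc3[nH]cc(-c4nnc(-c5cccnc5)o4)c(=O)c3c2)cc1` gives 14.7%;
compound 2 `N#Cc1ccc(-c2cnc3[nH]cc(-c4nnc(-c5ccc(Cl)cc5)o4)c(=O)c3c2)cc1` gives 18.3%;
compound 3 `O=c1c(-c2nnc(-c3ccc(Cl)cc3)o2)c[nH]c2ncc(-c3ccccc3)cc12` gives 21.6%.

Compound 1 sits at the smallest of the three numbers, though its gaps to compound 2 and to compound 3 are both within the scatter. Compound 4 `CS(=O)(=O)c1ccc(-c2cnc3[nH]cc(-c4nnc(-c5ccccn5)o4)c(=O)c3c2)cc1` is not yet measured. It differs from compound 1 in one place: pyridin-2-yl in place of pyridin-3-yl on an aromatic carbon. Within the data shown here, no measured step changes the group on that carbon of the five-membered ring. Among the measured compounds shown here, the only single step known, a number 3.3 percentage points higher from compound 2 to compound 3 (within the scatter), concerns another part of the molecule and stays within the scatter. For the measured compounds named here, with no step bearing on the change, the expected movement a number 0.3 percentage points higher from compound 1 to compound 4 (within the scatter) is none beyond the scatter. Compound 4 is therefore estimated at 15%, in the range 5% to 28%.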

Compound 4, percent growth inhibition at one concentration: 16.2%
For compound 4 the middle estimate is 1.2 percentage points below the measured one; low and high end bracket the measured number.
By their numbers in this assay, from the lowest: compounds 1, 4, 2 and 3 (each within the scatter of the next).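

In this assay, the first step read at this position, pyridin-2-yl in place of pyridin-3-yl on the aromatic carbon of the five-membered ring, gives a number 1.5 percentage points higher from compound 1 to compound 4 (within the scatter) and thus no separation between the two isomers. Within this pair, the change from pyridin-3-yl to pyridin-2-yl leaves the read-out within the scatter. No evidence is available that bears on this result.

On these data alone, it remains open whether a group of another kind at this carbon, such as an amine, a carboxylic acid or a longer alkyl chain, would move the number beyond the scatter. Among these compounds, the pair also leaves open whether the same change would read alike on a core carrying a group other than the one in compound 1.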